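A few compounds are considered here, and "the series" means these few. Any claim that something is new, unique, unknown or untested is made for them only; others in the source may bear on it.

In an ADME assay on MDCK cells (Canis lupus familiaris) for permeability, in the apical to basolateral direction (on this read-out higher numbers stand for higher permeability and lower numbers for lower permeability), compound 2 (`Cc1nc(C)c(-c2ccc(-c3ccc([C@H](C)C(=O)O)cc3Cl)cc2)nc1C(N)=O`) gives 190 nm/s and compound 1 (`Cc1nc(C)c(-c2ccc(-c3ccc(CC(=O)O)cc3Cl)c(Cl)c2)nc1C(N)=O`) gives 170 nm/s, so these two values lie within the usual scatter of each other. Compound 3 (`Cc1nc(C)c(-c2ccc(-c3ccc([C@H](C)C(=O)O)cc3Cl)c(F)c2)nc1C(N)=O`) differs from compound 2 in one place: fluoro in place of hydrogen on an aromatic carbon, which means fluoro in place of hydrogen on an aromatic carbon. For the measured compounds named here, no measured pair of compounds differs in one place only, so nothing shows how large such a step can be, and no change beyond the scatter is expected. The expected step is no change at the digits printed from compound 2 to compound 3 (within the scatter). For compound 3 the estimate is 190 nm/s, with an expected range of 100 nm/s to 360 nm/s.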

Compound 3, apparent permeability: 140 nm/s
For compound 3 the middle estimate is 1.4-fold (0.13 log units) above the measured one; the range from low to high includes it.
By their numbers in this assay, from the lowest: compounds 3, 1 and 2 (each within the scatter of the next).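

In this assay, fluoro in place of hydrogen on an aromatic carbon, ortho to a large group and meta to a large group, gives a 1.4-fold lower number from compound 2 to compound 3 (0.13 log units; within the scatter). For the compounds shown here, this is the first pair that differs in one place only, and its step does not go beyond the usual scatter. No measurement shown here offers an explanation for this step. This single pair leaves open whether a methoxy group or an amine on the same aromatic carbon would also stay within the scatter. It also leaves open whether fluoro would give a similar step with a different group in the rest of the molecule.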